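This account rests on a few compounds, and the source may have more. Where it says the series, first, only, none or still open, it means among the compounds named here.

In an ADME assay on PC-12 cells (Rattus norvegicus) for cytotoxicity, read by WST assay, with a stated time of 24 h (a lower number here means that less compound is tolerated, a higher number that more compound is tolerated), compound 1 `O=C(/C=C/c1cccc(O)c1)CC(=O)/C=C/c1cccc(O)c1O` gives 38000 nM and compound 2 `O=C(/C=C/c1ccc(O)c(O)c1)CC(=O)/C=C/c1cc(O)ccc1O` gives 51000 nM. Compound 2 therefore stands within the usual scatter of compound 1. Compound 3 `O=C(/C=C/c1cc(O)ccc1O)CC(=O)/C=C/c1cc(O)ccc1O` differs from compound 2 in one place: 2,5-dihydroxyphenyl in place of 3,4-dihydroxyphenyl on a double-bonded chain carbon bound to a double-bonded chain carbon, with 2,5-dihydroxyphenyl in place of 3,4-dihydroxyphenyl on a double-bonded chain carbon bound to a double-bonded chain carbon. Within the data shown here, no measured step shows what such a change does in this assay, so no shift beyond the scatter is expected in either direction. The expected change is a 1.1-fold lower number from compound 2 to compound 3 (0.05 log units; within the scatter). Compound 3 is estimated at 45000 nM, with an expected range of 20000 nM to 100000 nM.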

Compound 3, half-maximal cytotoxic concentration in the PC-12 assay: 24000 nM
For compound 3 the middle estimate is 1.9-fold (0.27 log units) above the measured one; the measured number falls inside the stated range.
By their numbers in the PC-12 assay, from the lowest: compounds 3, 1 and 2 (each within the scatter of the next, the first and the last beyond it).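

Among these compounds, replacing 3,4-dihydroxyphenyl with 2,5-dihydroxyphenyl on a double-bonded chain carbon bound to a double-bonded chain carbon gives the first step beyond the scatter in the PC-12 assay, a 2.1-fold lower number from compound 2 to compound 3 (0.33 log units; beyond the scatter). The two compounds have the same atoms, joined differently, so this rearrangement alone is enough to move the number. In a physicochemical assay for solubility, using the shake flask method, with a stated time of 12 h (on this read-out lower numbers stand for lower solubility and higher numbers for higher solubility), compound 2 gives 54000 nM and compound 3 gives 5000 nM. In the physicochemical assay the same change has a much larger effect on solubility: the measured solubility of compound 2, 54000 nM, and of compound 3, 5000 nM, an 11-fold lower number (1.03 log units; beyond the scatter)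

From the compounds shown here alone, whether the two shifts are linked remains open. It is also unknown how a carboxylic acid or an amine on the aromatic ring would behave at this place.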